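The source may hold more compounds than are shown below. What is called first, only, known or untested is meant among the compounds shown, and "the series" means these compounds.

In a functional assay on MT2 cells (Homo sapiens) for cytotoxicity, read by MTT assay (on this read-out lower numbers stand for higher toxicity in this test and higher numbers for lower toxicity in this test), compound 1 `COc1ccc(Nc2nccs2)cc1OCC=C(C)C` gives 42000 nM, compound 2 `CCc1ccc(Nc2nccs2)cc1OCC=C(C)C` gives 31000 nM, and compound 3 `CC(C)=CCOc1cc(Nc2nccs2)ccc1C#N` gives 750 nM, the lowest of the three numbers. The measured steps all concern one aromatic carbon: a 1.4-fold lower number from compound 1 to compound 2 (0.13 log units; within the scatter) stays within the scatter, while a 56-fold lower number from compound 1 to compound 3 (1.75 log units; beyond the scatter) and a 41-fold lower number from compound 2 to compound 3 (1.62 log units; beyond the scatter) are large and both introduce cyano. Compound 4 `N#Cc1ccc(Nc2nccs2)cc1OCc1cccs1` keeps that cyano and differs elsewhere: thiophen-2-yl in place of 2-methylprop-1-en-1-yl on a saturated chain carbon bound to an oxygen on an aromatic ring. Thiophen-2-yl stands in place of 2-methylprop-1-en-1-yl on a saturated chain carbon bound to an oxygen on an aromatic ring. Going by the values given here, no measured step covers this place, so no step beyond the scatter is expected, with only a slight lean toward a higher number. The estimated step is a 1.6-fold higher number from compound 3 to compound 4 (0.20 log units; within the scatter). For compound 4 the expected value is 1200 nM, with an estimated range of 250 nM to 6000 nM.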

Compound 4, half-maximal cytotoxic concentration: 4100 nM
For compound 4 the middle estimate is 3.4-fold (0.53 log units) below the measured one; the range from low to high includes it.
By their numbers in this assay, from the lowest: compound 3; then compound 4; then compounds 2 and 1 (each within the scatter of the next).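

In this assay, the group on a saturated chain carbon bound to an oxygen on an aromatic ring also affects the number, not just the cyano-bearing aromatic carbon: thiophen-2-yl in place of 2-methylprop-1-en-1-yl gives a 5.5-fold higher number from compound 3 to compound 4 (0.74 log units; beyond the scatter). With the cyano kept, this change lies beyond the scatter, so the earlier cyano steps do not account for all of the variation in this series. Nothing available explains this shift.

From the compounds shown here alone, it remains open whether a phenyl ring or an amine at this place would give a lower or higher number. Going by these compounds, it is also open whether thiophen-2-yl has the same effect when methoxy or ethyl replaces the cyano.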